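Swapping the pendant aryl group on an imidazopyrazine core

A few compounds are considered here, and "the series" means these few. Any claim that something is new, unique, unknown or untested is made for them only; others in the source may bear on it.

Measured so far:
Compound 1: `O=Cc1ccc(-c2cn3ccnc3c(-c3ccc4ncn(C5CCCCC5)c4c3)n2)cc1` gives 37.4%
Compound 2: `Fc1ccc(-c2cn3ccnc3c(-c3ccc4ncn(C5CCCCC5)c4c3)n2)cc1` gives 0.69%

Both compounds were tested in a functional assay on NCI/ADR-RES cells (Homo sapiens) for inhibition, read by sulforhodamine B assay, with a stated time of 48 h, tested at 10 uM; a higher number here means more inhibition at the concentration tested (going by the name of the read-out), a lower number less inhibition. Among the measured compounds shown here, compound 2 stands at the bottom of the two numbers available, and the only neighbour is compound 1, whose value is higher by a margin well beyond the usual scatter: a number 36.7 percentage points lower from compound 1 to compound 2 (beyond the scatter). That single step shows that exchanging one small group on the pendant six-membered carbon ring can move the read-out a long way.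

Compound 3, `COc1ccccc1-c1cn2ccnc2c(-c2ccc3ncn(C4CCCCC4)c3c2)n1`, has not yet been measured. It differs from compound 2 in one place: 2-methoxyphenyl in place of 4-fluorophenyl on an aromatic carbon. For the measured compounds named here, the change again touches only the pendant ring, so the step from compound 1 to compound 2 is the one comparison that bears on it, and it was large. Going by the values given here, no measured pair shows what a 2-methoxyphenyl group does, so the direction is uncertain; a rise from the very low value of compound 2 seems more likely than a further fall, but a large rise is not assured.

For compound 3 the expected outcome in this assay is 12%, with a range from 0% to 40%, which means an expected step of a number 11.3 percentage points higher from compound 2 to compound 3 (beyond the scatter).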

Compound 3, a percentage reported as inhibition, at one concentration (the size of the read-out at that concentration, not a potency): 0.06%
For compound 3 the middle estimate is 11.9 percentage points above the measured one; low and high end bracket the measured number.
By their numbers in this assay, from the lowest: compounds 3 and 2 (each within the scatter of the next); then compound 1.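

In this assay, 2-methoxyphenyl in place of 4-fluorophenyl gives a number 0.6 percentage points lower from compound 2 to compound 3 (within the scatter), so these two pendant rings cannot be told apart here, even though they carry different groups at different places on the ring. Compound 1 now stands apart from two different replacements rather than one, with a second large step of a number 37.3 percentage points lower from compound 1 to compound 3 (beyond the scatter), and among these three compounds only the 4-formylphenyl ring gives a value clearly above the others. Nothing measured here explains why that ring differs from the other two.

On these data alone, it remains open whether the value of compound 1 depends on the formyl group itself, or whether a carboxylic acid, an acetyl group or an aminomethyl group on the ring would keep it. A 2-formylphenyl ring would help separate the effect of the group from the effect of where it stands, since the two formyl-free rings alone cannot settle that question.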